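Working notes on the shared core: step to compound 4

This account rests on a few compounds, and the source may have more. Where it says the series, first, only, none or still open, it means among the compounds named here.

Compound 2 `Cc1ccc(OCC(=O)Nc2ccc(OCC(=O)O)c(F)c2)cc1` gives the lowest of the three numbers in a functional assay on CHO cells for agonist activity at Free fatty acid receptor 1 (Homo sapiens), read by FLIPR, tested at 100 nM (on this read-out higher numbers stand for a stronger effect at the one concentration tested and lower numbers for a weaker effect), at 31.2%. Compound 3 `COc1cccc(OCC(=O)Nc2ccc(OCC(=O)O)c(F)c2)c1` gives 31.7%, and a number 0.5 percentage points higher from compound 2 to compound 3 (within the scatter) shows the two within the scatter of each other. Compound 1 `Cc1cccc(OCC(=O)Nc2ccc(OCC(=O)O)c(F)c2)c1` gives 45.4%; both a number 14.2 percentage points lower from compound 1 to compound 2 (beyond the scatter) and a number 13.7 percentage points lower from compound 1 to compound 3 (beyond the scatter) are beyond the scatter. Compound 4 `O=C(O)COc1ccc(NC(=O)COc2ccc(OC(F)(F)F)cc2)cc1F` differs from compound 2 by trifluoromethoxy in place of methyl on an aromatic carbon. Going by the values given here, no measured step exchanges a methyl for a trifluoromethoxy; the nearest is a number 13.7 percentage points lower from compound 1 to compound 3 (beyond the scatter), also a swap of one group on an aromatic carbon, and it was modest. A step of similar size in either direction, or none beyond the scatter, is therefore expected. Compound 4 is estimated at 33%, with a range from 18% to 48%. That corresponds to an expected step of a number 1.8 percentage points higher from compound 2 to compound 4 (within the scatter).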

Compound 4, a percentage reported as activity, at one concentration (the size of the read-out at that concentration, not a potency): 6.45%
Compound 4: middle estimate off by 26.6 percentage points, on the high side, outside the stated range (below it).
By their numbers in this assay, from the lowest: compound 4; then compounds 2 and 3 (each within the scatter of the next); then compound 1.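

In this assay, trifluoromethoxy on the aromatic carbon para to a large group gives a number 24.8 percentage points lower from compound 2 to compound 4 (beyond the scatter), so the group at this position can lower the number substantially. This step is larger than any among compounds 1 to 3, where this position carries only methyl or nothing beyond hydrogen. Nothing available accounts for the drop.

Compound 4 alone cannot separate the effect of the oxygen from that of the fluorines. On these data alone, a trifluoromethyl or a chlorine at this position would test that, and whether trifluoromethoxy in place of the methyl of compound 1 gives a similar step also stays open.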